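Alkoxy variation on the shared core: compound 4

The compounds below may be only part of what the source reports. "The series", "measured", "known", "first", "only" and "open" are said of these compounds alone.

Measured so far:
- compound 1 `C[C@H](Oc1ccc(S(C)(=O)=O)cc1C(=O)N1Cc2ccc(-c3ccccn3)cc2C1)C(F)(F)F`: 84 nM
- compound 2 `C[C@H](Oc1ccc(S(C)(=O)=O)cc1C(=O)N1Cc2ccc(C3CCOCC3)cc2C1)C(F)(F)F`: 14 nM
- compound 3 `CC(C)Oc1ccc(S(C)(=O)=O)cc1C(=O)N1Cc2ccc(C3CCOCC3)cc2C1`: 28 nM

In an assay on CHO cells for inhibition of sodium- and chloride-dependent glycine transporter 1 (Homo sapiens), read by scintillation counting (on this read-out lower numbers stand for an effect already at smaller amounts and higher numbers for an effect only at larger amounts of compound), compound 3 gives the second highest of the three numbers. Its nearest neighbour is compound 2, a gap that lies within the scatter; its furthest is compound 1, a gap that lies beyond it. Within the data shown here, the only step that is clearly beyond the scatter is a 6.0-fold lower number from compound 1 to compound 2 (0.78 log units; beyond the scatter), and that change sits on an aromatic carbon, not on the oxygen that is varied here.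

Compound 4 `CS(=O)(=O)c1ccc(OCCC(F)(F)F)c(C(=O)N2Cc3ccc(C4CCOCC4)cc3C2)c1` differs from compound 3 in one place: 3,3,3-trifluoropropyl in place of isopropyl on an oxygen on an aromatic ring. The step that bears on it directly is a 2.0-fold higher number from compound 2 to compound 3 (0.30 log units; within the scatter), the earlier exchange on the same oxygen, which stayed within the scatter. Both changes on this oxygen keep a fluorine-free or trifluoromethyl-bearing short alkyl group; the data give no case in which such an exchange moved the number beyond the scatter. Accordingly no step beyond the scatter is expected from compound 3 to compound 4, i.e. a 1.1-fold lower number from compound 3 to compound 4 (0.05 log units; within the scatter) is the expected size. For compound 4 the estimate in this assay is 25 nM, with a range from 10 nM to 70 nM.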

Compound 4, half-maximal effective concentration: 137 nM
Compound 4: the middle estimate sits 5.5-fold (0.74 log units) below what was measured, and the stated range ends below it.
By their numbers in this assay, from the lowest: compounds 2 and 3 (each within the scatter of the next); then compounds 1 and 4 (each within the scatter of the next).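

In this assay, among these compounds, exchanging isopropyl for 3,3,3-trifluoropropyl on the oxygen gives a 4.9-fold higher number from compound 3 to compound 4 (0.69 log units; beyond the scatter), the first step beyond the scatter at this position, so this oxygen substituent can move the number after all. Carrying a trifluoromethyl group does not by itself set the number, since 3,3,3-trifluoropropyl in place of 1-(trifluoromethyl)ethyl gives a 9.8-fold higher number from compound 2 to compound 4 (0.99 log units; beyond the scatter) even though both groups hold one. Among the three compounds varied here, the branched groups of compound 2 and compound 3 stay within the scatter of each other, while the straight chain of compound 4 stands apart from both, a pattern resting on these three compounds alone.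

Nothing among the data shown explains this step. With only one straight chain in the set, chain shape and fluorine placement cannot be separated, and a plain propyl group on the same oxygen, set against both compound 3 and compound 4, would bear directly on that question, as would a longer chain such as butyl.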